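Swapping methylsulfanyl for methylamino in compound 2

A few compounds are considered here, and "the series" means these few. Any claim that something is new, unique, unknown or untested is made for them only; others in the source may bear on it.

In a functional assay on HCT-116 cells (Homo sapiens), read by MTT assay, with a stated time of 72 h (a higher number here means a weaker inhibitor, a lower number a stronger inhibitor), compound 1 `CSc1ncnc2c1c(-c1cccs1)cn2[C@@H]1O[C@H](CO)[C@@H](O)[C@H]1O` gives > 20000 nM, which is a limit and not a number. In the same test, compound 2 `CSc1ncnc2c1c(-c1ccsc1)cn2[C@@H]1O[C@H](CO)[C@@H](O)[C@H]1O` gives > 20000 nM, again only a limit. Compound 3 `C#Cc1cn([C@@H]2O[C@H](CO)[C@@H](O)[C@H]2O)c2ncnc(SC)c12`, which carries ethynyl instead of a thiophene group, gives a true number of 30 nM for comparison. That contrast appears as an at least 660-fold lower number from compound 1 to compound 3 (2.82 log units; beyond the scatter) and as an at least 660-fold lower number from compound 2 to compound 3 (2.82 log units; beyond the scatter), both large. Moving between the two thiophene groups gives a step that the two limits leave unreadable from compound 1 to compound 2, so it tells us little.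

Compound 4 `CNc1ncnc2c1c(-c1ccsc1)cn2[C@@H]1O[C@H](CO)[C@@H](O)[C@H]1O` has methylamino in place of methylsulfanyl on an aromatic carbon, (methylamino in place of methylsulfanyl on an aromatic carbon), and keeps the thiophen-3-yl group. Among the measured compounds shown here, no measured step changes this site. The large steps came only from removing a thiophene group, which does not happen here, so no large drop is expected in this assay. The expected result is an at least 1.3-fold lower number from compound 2 to compound 4 (0.12 log units; that floor lies within the scatter), with no gain beyond the scatter as the likeliest outcome. Compound 4 is estimated at 15000 nM, within an expected range of 2000 nM to 40000 nM, and may well return only a limit.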

Compound 4, half-maximal inhibitory concentration: > 20000 nM
Compound 4 was reported as a limit; the forecaster's own chance of this, stated with the estimate: 60%; middle value at least 1.3-fold (0.12 log units) from the limit.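

Compound 2 and compound 4 both return only a limit and not a number, so no step can be read between them: the limit of > 20000 nM in this assay, at which 3 of the 4 values shown sit. The compounds shown leave open whether methylamino in place of methylsulfanyl changes activity, since no such pair here has two true numbers.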